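This account rests on a few compounds, and the source may have more. Where it says the series, first, only, none or still open, it means among the compounds named here.

In a functional assay on MCF7 cells (Homo sapiens) for inhibition, read by MTT assay, with a stated time of 3 days (a lower number here means a stronger inhibitor, a higher number a weaker inhibitor), compound 1 (`C/C=C/COc1cc(/C=C\c2cc(OC)c(OC)c(OC)c2)ccc1OC`) gives 5400 nM while compound 2 (`COc1ccc(/C=C/CCCOc2cc(/C=C\c3cc(OC)c(OC)c(OC)c3)ccc2OC)cc1`) gives 16000 nM and compound 3 (`COCOc1ccccc1/C=C/CCCOc1cc(/C=C\c2cc(OC)c(OC)c(OC)c2)ccc1OC`) gives 4400 nM. Compound 3 lies within the scatter of compound 1, so these two cannot be told apart, and compound 2 stands alone as the weakest inhibitor of the three.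

Compound 4 (`COc1ccc(/C=C\c2cc(OC)c(OC)c(OC)c2)cc1OCCC/C=C/c1ccc(F)cc1`) has not yet been measured. It keeps the shared core of compound 3 and swaps one group: 4-fluorophenyl in place of 2-(methoxymethoxy)phenyl on a double-bonded chain carbon bound to a double-bonded chain carbon.

The most relevant measured change is a 3.6-fold lower number from compound 2 to compound 3 (0.56 log units; beyond the scatter), made at this same place when 2-(methoxymethoxy)phenyl replaced 4-methoxyphenyl. The other change, a 3.0-fold higher number from compound 1 to compound 2 (0.47 log units; beyond the scatter), swapped the whole end of the chain. Both are modest, though beyond the scatter. Among the compounds with values here, no measured compound carries 4-fluorophenyl, so any forecast is loose. By name the entering group resembles the 4-methoxyphenyl of compound 2 at 16000 nM, which points to a number between those of compound 3 and compound 2.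

The expected change is a 1.9-fold higher number from compound 3 to compound 4 (0.29 log units; within the scatter), a modest move towards a higher number. For compound 4 the estimated value is 8500 nM, with an expected range from 3500 nM to 21000 nM.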

Compound 4, half-maximal inhibitory concentration: 16000 nM
Compound 4: middle estimate off by 1.9-fold (0.27 log units), on the low side; low and high end bracket the measured number.
By their numbers in this assay, from the lowest: compounds 3 and 1 (each within the scatter of the next); then compounds 2 and 4 (each within the scatter of the next).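

In this assay, replacing 2-(methoxymethoxy)phenyl with 4-fluorophenyl gives a 3.6-fold higher number from compound 3 to compound 4 (0.56 log units; beyond the scatter), and the longer fluorophenyl chain gives a 3.0-fold higher number from compound 1 to compound 4 (0.47 log units; beyond the scatter), so this new end group brings no gain over the short prop-1-en-1-yl chain of compound 1. The closest comparison is fluoro in place of methoxy on the aromatic carbon, with no change at the digits printed from compound 2 to compound 4 (within the scatter), so 4-fluorophenyl and 4-methoxyphenyl cannot be told apart here, and among the three compounds with an aromatic end group, only the 2-(methoxymethoxy)phenyl of compound 3 stands apart. Nothing measured here explains that difference.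

The compounds shown leave open whether compound 3 owes its lower number to the methoxymethoxy group itself or to where that group sits on the ring, a question that 2-methoxyphenyl and 4-(methoxymethoxy)phenyl at this same place could help separate. They also leave open how this position would respond to an end ring carrying an amine or a carboxylic acid.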